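Acetylated phenylpropanoids: capping the free phenol

The source may hold more compounds than are shown below. What is called first, only, known or untested is meant among the compounds shown, and "the series" means these compounds.

Compound 1 `CC(=O)OCCCc1ccc(O)c(O)c1` in a functional assay on HeLa cells (Homo sapiens) for inhibition, read by MTT assay, with a stated time of 48 h (a lower number here means a stronger inhibitor, a higher number a weaker inhibitor), gives 22000 nM.
Compound 2 `CC(=O)OC/C=C/c1ccc(OCc2ccccc2)c(OC(C)=O)c1` in this assay gives 42000 nM.
Compound 3 `COc1cc(CC(COC(C)=O)OC(C)=O)ccc1O` in this assay gives 60000 nM.

Compound 3 and compound 2 lie within the scatter of each other in this assay; compound 1 gives a lower number than compound 3, beyond the scatter. All three sit in the same weak region.

Compound 4 `C=CCOc1ccc(CC(COC(C)=O)OC(C)=O)cc1OC` is the next member, not yet measured. Relative to compound 3 the change is allyl in place of hydrogen on an oxygen on an aromatic ring. Among the compounds with values here, no pair of measured compounds differs by this single change, so the size of the step cannot be read from the set. With all three measured numbers close together, the expected step of a 1.2-fold lower number from compound 3 to compound 4 (0.08 log units; within the scatter) is small, not beyond the scatter, with no clear direction. Compound 4 is therefore estimated at 50000 nM, ranging from 20000 nM to 120000 nM.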

Compound 4, half-maximal inhibitory concentration: 96000 nM
Compound 4: middle estimate off by 1.9-fold (0.28 log units), on the low side, and the stated range covers the measured number.
By their numbers in this assay, from the lowest: compounds 1, 2, 3 and 4 (each within the scatter of the next, the first and the last beyond it).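

Within the data shown here, this is the first step that differs in one place: allyl in place of hydrogen on an oxygen on an aromatic ring gives a 1.6-fold higher number from compound 3 to compound 4 (0.20 log units; within the scatter) in this assay. On this core, then, the free hydroxy can be capped as allyloxy without a step that stands clear of the scatter. No measurement here bears on the reason for this outcome.

Going by these compounds, whether a carboxylic acid or an amine on a longer chain at this oxygen would give a step beyond the scatter remains open. So does whether the same change would read alike on the core of compound 1.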